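Fluoro for nitro in a level series

This account rests on a few compounds, and the source may have more. Where it says the series, first, only, none or still open, it means among the compounds named here.

In a functional assay on MCF7 cells (Homo sapiens) for cytotoxicity, read by MTT assay, with a stated time of 96 h (a lower number here means a stronger inhibitor, a higher number a weaker inhibitor), compound 1 `CCc1ccc(-c2ccc(-c3ccc(C(=N)N)cc3)o2)cc1` gives 3200 nM. Compound 2 `N=C(N)c1ccc(-c2ccc(-c3ccc([N+](=O)[O-])cc3)o2)cc1` gives 3200 nM, and compound 3 `N=C(N)c1ccc(-c2ccc(-c3cccc([N+](=O)[O-])c3)o2)cc1` gives 3000 nM. These three numbers lie within the scatter of one another, so compound 3 stands level with the other two and apart from neither.

The next compound, compound 4 `N=C(N)c1ccc(-c2ccc(-c3cccc(F)c3)o2)cc1`, keeps the core of compound 3 but carries fluoro in place of nitro on an aromatic carbon. Within the data shown here, the one measured step that bears on this change is no change at the digits printed from compound 1 to compound 2 (within the scatter), which also exchanged a group on an aromatic carbon and stayed within the scatter. Among the measured compounds shown here, no compound with fluoro has yet been measured, so this single step is thin support, and the range must stay wide. Going by that step, the expected change is no larger than the scatter: no change at the digits printed from compound 3 to compound 4 (within the scatter). For compound 4 the estimated value in this assay is 3000 nM, with an expected range from 1400 nM to 6500 nM.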

Compound 4, half-maximal inhibitory concentration: 2600 nM
Beside the measured number, compound 4's estimate is 1.2-fold (0.06 log units) above it; measured number inside the range.
By their numbers in this assay, from the lowest: compounds 4, 3, 1 and 2 (each within the scatter of the next).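

In this assay the exchange of nitro for fluoro on an aromatic carbon, meta to a large group, gives a 1.2-fold lower number from compound 3 to compound 4 (0.06 log units; within the scatter) and so stays within the scatter. Compound 4 is the first compound shown with fluoro, and it shows that at this place the whole nitro group, with its nitrogen, its oxygens and its hydrogen-bond acceptors, can give way to a single fluorine atom while the number stays level with that of compound 3. Nothing measured here gives a reason for this level result.

The compounds shown leave open whether an amine, a carboxylic acid or a longer chain at this place would also stay level. They also leave open whether fluoro would stay level in the place that nitro holds in compound 2.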